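Notes on the step from compound 3 to compound 4

The source may hold more compounds than are shown below. What is called first, only, known or untested is meant among the compounds shown, and "the series" means these compounds.

In a functional assay on RAW264.7 cells (Mus musculus) for inhibition, with stated times of 2 h and 24 h (on this read-out higher numbers stand for weaker inhibition and lower numbers for stronger inhibition), compound 1 (`COc1ccc(/C=C2/c3cc(OC)cc(OC)c3[C@@H](c3ccc(OC)cc3)[C@@H]2c2cc(OC)cc(OC)c2)cc1`) gives 6260 nM as its reading. Compound 3 (`COc1ccc([C@@H]2c3c(OC)cc(OC)cc3C(O)[C@H]2c2cc(OC)cc(OC)c2)cc1`) gives 7870 nM and so lies within the scatter of compound 1. Compound 2 (`COc1ccc([C@@H]2c3c(OC)cc(OC)cc3/C(=C/c3ccccc3)[C@H]2c2cc(OC)cc(OC)c2)cc1`) gives > 200000 nM and this is a limit of the assay, not a number.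

Compound 4 (`COc1cc(OC)cc([C@@H]2C(O)c3cc(OC)cc(OC)c3[C@H]2c2ccccc2)c1`) differs from compound 3 by hydrogen in place of methoxy on an aromatic carbon, para to a large group, so that 4-methoxyphenyl becomes phenyl (hydrogen in place of methoxy on an aromatic carbon).

For the measured compounds named here, one measured step bears on this change. The same exchange gave an at least 31-fold higher number from compound 1 to compound 2 (1.50 log units; beyond the scatter) and that step is large and beyond the scatter. Its size rests on the limit of > 200000 nM in this assay, at which 1 of the 3 values shown sits, and is therefore only a lower bound. That exchange falls on a different aromatic ring, and compound 1 and compound 3 also differ elsewhere in the structure, so it is a single, indirect precedent. A higher number is expected in this assay for the new step, but a smaller move than an at least 31-fold higher number from compound 1 to compound 2 (1.50 log units; beyond the scatter) suggests. The estimated change is a 3.2-fold higher number from compound 3 to compound 4 (0.50 log units; beyond the scatter) in this expectation. For compound 4 the estimate is 25000 nM with an expected range of 7000 nM to 150000 nM in this assay.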

Compound 4, half-maximal inhibitory concentration: 3380 nM
For compound 4 the middle estimate is 7.4-fold (0.87 log units) above the measured one, and the stated range ends above it.
By their numbers in this assay, from the lowest: compounds 4, 1 and 3 (each within the scatter of the next, the first and the last beyond it). At a limit, above all of these: compound 2.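

In this assay, going from 4-methoxyphenyl to phenyl on the core of compound 3 gives a 2.3-fold lower number from compound 3 to compound 4 (0.37 log units; beyond the scatter), so on this core the methoxy para to a large group is not required for the inhibition read here, and its loss does not weaken the result. Hydrogen in place of methoxy on an aromatic carbon therefore has no single direction in this series, and the outcome on one core does not carry over to the other: the same change on two cores in this assay, an at least 31-fold higher number (1.50 log units; beyond the scatter) from compound 1 to compound 2 and a 2.3-fold lower number (0.37 log units; beyond the scatter) from compound 3 to compound 4, at least 74-fold (1.87 log units) apart, beyond the scatter of two such steps Compound 2 stands at a limit of the assay, so the size of that gap is only a lower bound, though its direction is not in doubt: the limit of > 200000 nM in this assay, at which 1 of the 4 values shown sits.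

As far as these compounds go, whether a fluorine, a hydroxyl or an amine at this position would read like compound 3, like compound 4 or like neither stays open. Also open, from the compounds shown here alone, is whether the opposite directions follow the ring that carries the change or the rest of the core, since the two pairs differ in both.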